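The compounds below may be only part of what the source reports. "The series", "measured", "known", "first", "only" and "open" are said of these compounds alone.

Within the data shown here, compound 1 `O=C(Nc1ccccc1Br)C(Cl)Cl` is the only member of this small set with a number: in a functional assay on Bel-7402 cells (Homo sapiens) for antiproliferative activity, read by MTT assay, with a stated time of 72 h (on this read-out lower numbers stand for stronger inhibition and higher numbers for weaker inhibition), compound 1 gives 38200 nM. Compound 2 `O=C(Nc1cccc(F)c1)C(Cl)Cl` carries a fluoro on the ring instead, and in this assay compound 2 gives "not determined" (no result reported), so on the numbers shown it stands nowhere. Compound 3 `O=C(Nc1cccc(Br)c1)C(Cl)Cl` differs from compound 2 by bromo in place of fluoro on an aromatic carbon. Among the measured compounds shown here, with no measured pair to set a scale, neither size nor direction of the move to compound 3 in this assay can be fixed, and compound 3 is expected to sit near compound 1 because compound 1 gives 38200 nM. Compound 3 is therefore estimated at 30000 nM, within 8000 nM to 150000 nM.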

Compound 3, half-maximal inhibitory concentration: 7720 nM
For compound 3 the middle estimate is 3.9-fold (0.59 log units) above the measured one; the whole stated range lies above it.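

No step can be read from compound 2 to compound 3, as compound 2 has no number to set beside compound 3. On these data alone, what replacing fluoro with bromo does in this assay stays open. Nothing shown bears on why compound 3 gives its value.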